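A few compounds are considered here, and "the series" means these few. Any claim that something is new, unique, unknown or untested is made for them only; others in the source may bear on it.

Compound 1 `O=C1N/C(=N/c2csc(-c3ccc(Cl)cc3)c2)S/C1=C\c1ccccc1` gives 11200 nM.
Compound 2 `COc1ccc(/C=C2\S/C(=N\c3csc(-c4ccc(Cl)cc4)c3)NC2=O)cc1` gives 1300 nM.

Among the compounds with values here, in a functional assay on HCT-116 cells (Homo sapiens) for cytotoxicity, read by MTT assay, with a stated time of 72 h (on this read-out higher numbers stand for weaker inhibition and lower numbers for stronger inhibition), compound 2 holds the lowest number of the two, with compound 1 as its only neighbour. Within the data shown here, the one measured step, an 8.6-fold lower number from compound 1 to compound 2 (0.94 log units; beyond the scatter), concerns the same aromatic carbon that compound 3 `O=C1N/C(=N/c2csc(-c3ccc(Cl)cc3)c2)S/C1=C\c1ccc(F)cc1` now changes: fluoro in place of methoxy on an aromatic carbon. Among the measured compounds shown here, that step bears on the change, since the fluoro takes the place the methoxy held, but no measured step shows a fluoro itself. Compound 3 is therefore expected to land between the two measured numbers, a step of a 3.8-fold higher number from compound 2 to compound 3 (0.59 log units; beyond the scatter). The estimate for compound 3 is 5000 nM, ranging from 1500 nM to 15000 nM.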

Compound 3, half-maximal inhibitory concentration: 7400 nM
For compound 3 the middle estimate is 1.5-fold (0.17 log units) below the measured one; low and high end bracket the measured number.
By their numbers in this assay, from the lowest: compound 2; then compounds 3 and 1 (each within the scatter of the next).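

In this assay the exchange of 4-methoxyphenyl for 4-fluorophenyl gives a 5.7-fold higher number from compound 2 to compound 3 (0.76 log units; beyond the scatter) and shows that the lower number of compound 2 does not carry over to fluoro at this position. Fluoro in place of hydrogen gives a 1.5-fold lower number from compound 1 to compound 3 (0.18 log units; within the scatter) and so separates compound 3 from compound 1 by no more than the scatter. Nothing measured here explains the difference between methoxy and fluoro. On these data alone, whether the lower number stays with an ethoxy group or a dimethylamino group on this aromatic carbon remains open.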